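Amide change on the shared core: secondary to tertiary

The source may report more compounds than this note shows. Statements on the series, on what has been measured and on what is new or still open speak of the compounds shown alone.

Three compounds have numbers in an assay on CHO cells for displacement of a labelled ligand from adenosine receptor A3 (Homo sapiens); a lower number here means a stronger inhibitor, a higher number a weaker inhibitor. Compound 1 `CNc1nc(Cl)nc2c1ncn2[C@@H]1O[C@H](C(=O)N2CCOCC2)[C@@H](O)[C@H]1O` gives 3890 nM. Compound 2 `O=C(NCC1CC1)[C@H]1O[C@@H](n2cnc3c(NCc4cccc(I)c4)nc(Cl)nc32)[C@H](O)[C@@H]1O` gives 3.63 nM. Compound 3 `O=C(NC1CCC1)[C@H]1O[C@@H](n2cnc3c(NCc4cccc(I)c4)nc(Cl)nc32)[C@H](O)[C@@H]1O` gives 18.2 nM, the second highest of the three numbers; it sits nearest compound 2 and far from compound 1. For the measured compounds named here, the one single-point step measured so far, a 5.0-fold higher number from compound 2 to compound 3 (0.70 log units; beyond the scatter), shows that changing the group on the amide nitrogen moves this assay by a modest amount. Compound 4 `O=C([C@H]1O[C@@H](n2cnc3c(NCc4cccc(I)c4)nc(Cl)nc32)[C@H](O)[C@@H]1O)N1CCOCC1` differs from compound 3 by morpholin-4-yl in place of cyclobutylamino on a carbonyl carbon. Going by the values given here, no measured step bears on this change directly: compound 1 also carries the morpholin-4-yl carbonyl but differs from compound 4 at a second place as well, so its value only shows that the morpholine amide is compatible with weak binding in this assay. The amide hydrogen is lost and the measured step from compound 2 to compound 3 shows the amide end is sensitive, so a rise in the number is expected. For compound 4 the estimate is 250 nM, within 40 nM to 1500 nM, an expected step of a 14-fold higher number from compound 3 to compound 4 (1.14 log units; beyond the scatter).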

Compound 4, inhibition constant: 513 nM
Compound 4: middle estimate off by 2.1-fold (0.31 log units), on the low side; low and high end bracket the measured number.
By their numbers in this assay, from the lowest: compound 2; then compound 3; then compound 4; then compound 1.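

In this assay, morpholin-4-yl in place of cyclobutylamino on the carbonyl carbon gives a 28-fold higher number from compound 3 to compound 4 (1.45 log units; beyond the scatter) and morpholin-4-yl in place of (cyclopropylmethyl)amino gives a 140-fold higher number from compound 2 to compound 4 (2.15 log units; beyond the scatter); both are large, whereas the change between the two groups that keep the amide hydrogen gives only a 5.0-fold higher number from compound 2 to compound 3 (0.70 log units; beyond the scatter). With the morpholin-4-yl carbonyl held constant, 3-iodophenyl in place of hydrogen on the saturated chain carbon bound to a nitrogen on an aromatic ring gives a 7.6-fold lower number from compound 1 to compound 4 (0.88 log units; beyond the scatter), so this modest gain leaves both morpholine amides far weaker than compound 2. No measurement available here explains the size of these steps.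

The compounds shown do not separate loss of the amide hydrogen from the presence of the morpholine ring. Dimethylamino or piperidin-1-yl on the carbonyl carbon would help make that distinction.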